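The compounds below may be only part of what the source reports. "The series", "measured", "known", "first", "only" and "open" are said of these compounds alone.

Measured so far:
compound 1, `COc1cc2ccc(=O)oc2cc1OCC(=O)c1ccccc1`, 3.4%
compound 2, `COc1cc2ccc(=O)oc2cc1OCC1CO1`, 62.2%

In a functional assay on HUVEC cells (Homo sapiens) for inhibition, read by MTT assay, with a stated time of 24 h, tested at 10 uM (on this read-out lower numbers stand for less inhibition of growth and higher numbers for more inhibition of growth at the one concentration tested), compound 2 gives 62.2%, the highest of the two numbers, while compound 1 gives 3.4%, a gap beyond the scatter. Compound 3, `COc1cc2ccc(=O)oc2cc1OCCNC(C)C`, has not yet been measured; it differs from compound 2 by (isopropylamino)methyl in place of oxiran-2-yl on a saturated chain carbon bound to an oxygen on an aromatic ring. Among the compounds with values here, no step between two measured compounds is known, so the size of this change can only be judged from the two numbers at hand. Compound 3 is expected to inhibit growth less, an estimated step of a number 32.2 percentage points lower from compound 2 to compound 3 (beyond the scatter) in this assay. Compound 3 is estimated at 30%, within 5% to 60%.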

Compound 3, percent growth inhibition at one concentration: 0.1%
The estimate for compound 3 lay 29.9 percentage points above the measured number, and the stated range ends above it.
By their numbers in this assay, from the lowest: compounds 3 and 1 (each within the scatter of the next); then compound 2.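

In this assay, within the data shown here, the change from oxiran-2-yl to (isopropylamino)methyl on a saturated chain carbon bound to an oxygen on an aromatic ring gives a number 62.1 percentage points lower from compound 2 to compound 3 (beyond the scatter) and is the first step read at this place. It shows that growth inhibition at this position depends strongly on the group carried by the chain. Nothing at hand explains the size of this drop.

As far as these compounds go, whether the loss of the three-membered ring or the arrival of the amine counts for more stays open. A plain propyl chain or a 2,3-dihydroxypropyl chain at this place would help separate the two.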